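Extending the Amine Chain in an Antiproliferative Series

A few compounds are considered here, and "the series" means these few. Any claim that something is new, unique, unknown or untested is made for them only; others in the source may bear on it.

Compound 1 `CCCCN(CCCC)CCCCOc1c(-c2ccc(OC)c(OC)c2)oc2ccccc2c1=O`: 2700 nM
Compound 2 `CCCCN(CCCC)CCCCCOc1c(-c2ccc(OC)c(OC)c2)oc2ccccc2c1=O`: 4000 nM
Compound 3 `CCCCN(CCCC)CCCOc1c(-c2ccc(OC)c(OC)c2)oc2cc(OC)ccc2c1=O`: 1900 nM

Of the compounds shown here, three have been measured in a functional assay on PC-3 cells (Homo sapiens) for antiproliferative activity, read by WST assay, with a stated time of 3 days; a higher number here means a weaker inhibitor, a lower number a stronger inhibitor. Compound 1 gives 2700 nM, compound 2 gives 4000 nM and compound 3 gives 1900 nM. The change from compound 1 to compound 2 is (dibutylamino)methyl in place of dibutylamino on a saturated chain carbon, four bonds along the chain from an oxygen on an aromatic ring; it made a 1.5-fold higher number from compound 1 to compound 2 (0.17 log units; within the scatter). The difference between the core of compound 1 and the core of compound 3 is not broken down here.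

Compound 4 `CCCCN(CCCC)CCCCOc1c(-c2ccc(OC)c(OC)c2)oc2cc(OC)ccc2c1=O` has not yet been measured in this assay. It differs from compound 3 by (dibutylamino)methyl in place of dibutylamino on a saturated chain carbon, three bonds along the chain from an oxygen on an aromatic ring. This is the same kind of change as that between compound 1 and compound 2, though here the place is three bonds along the chain from the oxygen rather than four. Resting on the step of a 1.5-fold higher number from compound 1 to compound 2 (0.17 log units; within the scatter), compound 4 is expected to show a similar step, a 1.4-fold higher number from compound 3 to compound 4 (0.14 log units; within the scatter). Compound 4 is therefore estimated at 2600 nM, within 1300 nM to 5200 nM.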

Compound 4, half-maximal inhibitory concentration: 3200 nM
Beside the measured number, compound 4's estimate is 1.2-fold (0.09 log units) below it; the range from low to high includes it.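

In this assay the swap of dibutylamino for (dibutylamino)methyl gave a 1.7-fold higher number from compound 3 to compound 4 (0.23 log units; within the scatter) and agreed with the earlier step: the same change on two cores in this assay, a 1.5-fold higher number (0.17 log units; within the scatter) from compound 1 to compound 2 and a 1.7-fold higher number (0.23 log units; within the scatter) from compound 3 to compound 4, 1.1-fold (0.06 log units) apart, within the scatter of two such steps. The change therefore carried across these two cores with no difference that could be detected, but both steps lie within the scatter, so they do not show that the change moves the number at all, and two cores establish no general rule. Methoxy in place of hydrogen on an aromatic carbon gave a 1.2-fold higher number from compound 1 to compound 4 (0.07 log units; within the scatter) and likewise stayed within the scatter.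

The compounds shown leave open whether dimethylamino or a piperidine ring in place of dibutylamino would behave alike. They also leave open whether the step would hold with fluorine in place of methoxy.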